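Compound 2 to compound 3: adding a trifluoromethyl group

A few compounds are considered here, and "the series" means these few. Any claim that something is new, unique, unknown or untested is made for them only; others in the source may bear on it.

The series is read in a functional assay on DU-145 cells (Homo sapiens) for antiproliferative activity, read by MTT assay, with a stated time of 72 h; on this read-out lower numbers stand for stronger inhibition and higher numbers for weaker inhibition. Compound 1 `O=[N+]([O-])c1ccc(COc2ccc(Nc3ncnc4cc5c(cc34)OCCOCCO5)cc2)cc1` gives > 100000 nM, which is a limit of the assay and not a number. Compound 2 `c1ccc(COc2ccc(Nc3ncnc4cc5c(cc34)OCCOCCOCCO5)cc2)cc1` gives > 100000 nM, which is also a limit and not a number. Among the compounds with values here, compound 2 therefore has no numerical place, and the only other value offers no number to compare it with. The two results read together as the limit of > 100000 nM in this assay, at which 2 of the 2 values shown sit.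

Compound 3 `FC(F)(F)c1ccc(COc2ccc(Nc3ncnc4cc5c(cc34)OCCOCCOCCO5)cc2)cc1` has trifluoromethyl in place of hydrogen on an aromatic carbon of compound 2, para to a large group, so that benzyl becomes 4-(trifluoromethyl)benzyl: trifluoromethyl in place of hydrogen on an aromatic carbon. Within the data shown here, no measured step in this assay shows the effect of such a change. The expectation therefore rests on compound 2, with its limit of > 100000 nM. The expected result is another limit, and any number that does appear should lie on the side of stronger inhibition. The expected change is a number no higher from compound 2 to compound 3 (the limit leaves the size open), which would be no step beyond the scatter. For compound 3 the estimated value is 100000 nM, with an expected range of 30000 nM to 200000 nM.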

Compound 3, half-maximal inhibitory concentration: > 100000 nM
Compound 3: a limit, no number; the forecaster's own chance of this, stated with the estimate: 75%; the middle value sits exactly at the limit.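

Compound 3 gives > 100000 nM in this assay, which is a limit and not a number, and no step can be read from compound 2 to compound 3, since the series stands at: the limit of > 100000 nM in this assay, at which 3 of the 3 values shown sit.

The compounds shown leave open what trifluoromethyl in place of hydrogen does to antiproliferative activity, and which compound, if any, would give a number in this assay.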